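The compounds below may be only part of what the source reports. "The series", "measured", "known", "first", "only" and "open" are said of these compounds alone.

The set here consists of three thioureas that share one core and differ only in the ring attached to the second amide-type nitrogen. Compound 1 `FC(F)(F)c1cccc(NC(=S)Nc2cccc(Br)c2)c1` gives 9200 nM in an ADME assay on MT4 cells (Homo sapiens) for cytotoxicity; a lower number here means that less compound is tolerated, a higher number that more compound is tolerated. Compound 2 `COc1cccc(NC(=S)Nc2cccc(C(F)(F)F)c2)c1` gives 26000 nM in this assay, and compound 3 `FC(F)(F)c1cccc(NC(=S)Nc2ccc(Cl)cc2)c1` gives 6800 nM. Among these three numbers compound 3 holds the lowest, with compound 1 nearest to it and compound 2 furthest away; the gap to compound 1 is within the scatter, the gap to compound 2 beyond it. The move from compound 1 to compound 2 is a 2.8-fold higher number from compound 1 to compound 2 (0.45 log units; beyond the scatter), while the move from compound 1 to compound 3 is a 1.4-fold lower number from compound 1 to compound 3 (0.13 log units; within the scatter).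

Compound 4 `FC(F)(F)c1cccc(NC(=S)Nc2ccc(I)cc2)c1` has not yet been measured. It differs from compound 3 by iodo in place of chloro on an aromatic carbon. Within the data shown here, the one step that bears directly on a halogen exchange on this ring, from compound 1 to compound 3, stayed within the scatter, so a change of one halogen for another has so far left this assay nearly unmoved. The step from compound 3 to compound 4 is therefore expected to be a 1.1-fold lower number from compound 3 to compound 4 (0.05 log units; within the scatter), with no clear direction. Compound 4 is estimated at 6000 nM, within a range from 3000 nM to 13000 nM.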

Compound 4, half-maximal cytotoxic concentration: 10000 nM
Compound 4: middle estimate off by 1.7-fold (0.22 log units), on the low side, and the stated range covers the measured number.
By their numbers in this assay, from the lowest: compounds 3, 1 and 4 (each within the scatter of the next); then compound 2.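

In this assay, among these compounds, iodo in place of chloro, para to a large group, gives a 1.5-fold higher number from compound 3 to compound 4 (0.17 log units; within the scatter) and so supplies the first reading of one halogen exchanged for another at a single place on the ring. Replacing 3-bromophenyl with 4-iodophenyl gives a 1.1-fold higher number from compound 1 to compound 4 (0.04 log units; within the scatter) and adds a second step that stays inside the scatter, so compound 1, compound 3 and compound 4 cannot be told apart here, while the one step shown to leave the scatter is still the methoxy change, a 2.8-fold higher number from compound 1 to compound 2 (0.45 log units; beyond the scatter). The earlier step between compound 1 and compound 3 also changed where the halogen sat, so it was not such a reading. Nothing given here accounts for the size of either new step.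

With only chloro and iodo read at this place, the compounds shown leave open whether a group other than a halogen, such as an amine, a carboxylic acid or a longer chain, would move the number beyond the scatter. They also leave open whether methoxy para to a large group would repeat the step seen with compound 2, and whether the halogen exchange would read the same on a different partner ring.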